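Swapping the amide aryl group: chloro to methoxy

The source may hold more compounds than are shown below. What is called first, only, known or untested is meant among the compounds shown, and "the series" means these compounds.

Measured compounds:
Compound 1, `O=C(Nc1cccc(-c2oc3cc(-c4ccc(F)cc4)ccc3c(=O)c2O)c1)c1ccc(F)cc1`: 14600 nM
Compound 2, `O=C(Nc1cccc(-c2oc3cc(-c4ccc(F)cc4)ccc3c(=O)c2O)c1)c1ccc(Cl)cc1`: 9140 nM

Both compounds were tested in a functional assay on GTL 16 cells for antiproliferative activity against GTL 16 cell line (Homo sapiens), read by CCK-8 assay, with a stated time of 72 h; on this read-out lower numbers stand for stronger inhibition and higher numbers for weaker inhibition. Compound 2 gives 9140 nM, the lowest of the two numbers; compound 1 gives 14600 nM, and the step of a 1.6-fold lower number from compound 1 to compound 2 (0.20 log units; within the scatter) falls within the scatter, so the two cannot be told apart.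

Compound 3, `COc1ccccc1C(=O)Nc1cccc(-c2oc3cc(-c4ccc(F)cc4)ccc3c(=O)c2O)c1`, has not yet been measured in this assay. It differs from compound 2 by 2-methoxyphenyl in place of 4-chlorophenyl on a carbonyl carbon. Among the measured compounds shown here, the only measured step, a 1.6-fold lower number from compound 1 to compound 2 (0.20 log units; within the scatter), swaps one halogen for another at the same spot; no measured step exchanges the whole aryl group or introduces a methoxy group, so there is no direct guide. Since that one step stayed within the scatter, the expectation for compound 3 is a number close to that of compound 2, with no step beyond the scatter in either direction, though the lack of any guiding step leaves the estimate broad.

Compound 3 is therefore expected to give about 12000 nM in this assay, within 5000 nM to 30000 nM, an estimated step of a 1.3-fold higher number from compound 2 to compound 3 (0.12 log units; within the scatter).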

Compound 3, half-maximal inhibitory concentration: 6370 nM
The estimate for compound 3 lay 1.9-fold (0.28 log units) above the measured number; low and high end bracket the measured number.
By their numbers in this assay, from the lowest: compounds 3, 2 and 1 (each within the scatter of the next, the first and the last beyond it).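

Replacing the whole aryl group on the carbonyl carbon, rather than only a halogen, leaves the number in this assay almost unmoved in one comparison: 2-methoxyphenyl in place of 4-chlorophenyl gives a 1.4-fold lower number from compound 2 to compound 3 (0.16 log units; within the scatter), so these two groups cannot be told apart at this position. Against 4-fluorophenyl, the same 2-methoxyphenyl group gives a 2.3-fold lower number from compound 1 to compound 3 (0.36 log units; beyond the scatter), the first step in this series to pass beyond the scatter, although it is only a modest one, and compound 2 stays within the scatter of both neighbours. Together these steps show that this position accepts an aryl group carrying either a halogen or a methoxy group without a large shift in the number, but nothing available explains the steps.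

Compound 3 differs from compound 1 and compound 2 in both the substituent and its place on the ring, so a 4-methoxyphenyl group would be needed to separate those two changes. The compounds shown also leave open how this position responds to a ring carrying an amine or a carboxylic acid, or to a simple alkyl chain in place of the aryl group.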